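The source may report more compounds than this note shows. Statements on the series, on what has been measured and on what is new or still open speak of the compounds shown alone.

Measured compounds:
- Compound 1, `O=C(Nc1cccc(-n2cc(-c3ccncc3)c(-c3cc(O)cc(Cl)c3)n2)c1)Nc1ccc(Cl)c(Cl)c1`, gives -61% in a functional assay on HCT-116 cells (Homo sapiens) for inhibition, read by sulforhodamine B assay, with a stated time of 48 h, tested at 100 uM; on this read-out lower numbers stand for a stronger effect and higher numbers for a weaker effect at the one concentration tested.
- Compound 2, `COc1cc(Cl)cc(-c2nn(-c3cccc(NC(=O)Nc4ccc(Cl)c(C(F)(F)F)c4)c3)cc2-c2ccncc2)c1`, gives -94% in this assay.
- Compound 3, `COc1cc(Cl)cc(-c2nn(-c3cccc(NC(=O)Nc4cc(C(F)(F)F)cc(C(F)(F)F)c4)c3)cc2-c2ccncc2)c1`, gives -88% in this assay.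

Compound 3 stands second highest of the three numbers. Its nearest neighbour is compound 2, whose value lies within the scatter of that of compound 3, so the two cannot be told apart. Compound 1 stands further off, with a number beyond the scatter higher than that of compound 3.

Compound 4, `COc1cc(Cl)cc(-c2nn(-c3cccc(NC(=O)Nc4cccc(C(F)(F)F)c4)c3)cc2-c2ccncc2)c1`, has not yet been measured in this assay. It differs from compound 3 in one place: hydrogen in place of trifluoromethyl on an aromatic carbon. Among the measured compounds shown here, no measured pair shows a step of this kind, so its size must be guessed from the structural change alone. Since compound 3 keeps a trifluoromethyl group at the other place and compound 4 still carries one such group, the estimated step of a number 10 percentage points higher from compound 3 to compound 4 (within the scatter) is expected to be small, tending toward a weaker effect but not clearly beyond the scatter. For compound 4 the expected value in this assay is -78%, within a range from -98% to -50%.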

Compound 4, a percentage reported as activity, at one concentration (the size of the read-out at that concentration, not a potency): -81%
Compound 4: middle estimate off by 3 percentage points, on the high side, and the stated range covers the measured number.
By their numbers in this assay, from the lowest: compounds 2, 3 and 4 (each within the scatter of the next, the first and the last beyond it); then compound 1.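

Among the compounds shown here, compound 4 shows what the ring carrying the urea side keeps when only one trifluoromethyl group remains on it, read in this assay. Losing the second trifluoromethyl group gives a step that stays within the scatter (a number 7 percentage points higher from compound 3 to compound 4 (within the scatter)), so this place tolerates hydrogen in that comparison. Losing the chloro group gives a modest step beyond the scatter (a number 13 percentage points higher from compound 2 to compound 4 (beyond the scatter)), so the effect of removing a group on this ring depends on which group leaves, or on the carbon it leaves.

The compounds shown cannot separate those two readings, as the chloro and trifluoromethyl groups do not sit on the same carbon. They also leave open how a methoxy group, an amine or a nitrile would read on this ring. Nothing given here accounts for either step.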